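This account rests on a few compounds, and the source may have more. Where it says the series, first, only, none or still open, it means among the compounds named here.

Of the compounds shown here, three have been measured in an assay on Sf9 cells for inhibition of protein deacetylase HDAC6 (Homo sapiens), read by fluorescence, with a stated time of 40 min, tested at 100 nM; on this read-out higher numbers stand for more inhibition at the one concentration tested (going by the name of the read-out) and lower numbers for less inhibition. Compound 1 `Cc1ccccc1-n1nc(-c2ccccc2)nc1CNc1ccc(C(=O)NO)cc1` gives 57.1%, compound 2 `O=C(NO)c1ccc(NCc2nc(-c3cccc4cnccc34)nn2-c2ccccc2)cc1` gives 40.2%, and compound 3 `Nc1ccccc1NC(=O)c1ccc(NCc2nc(-c3ccccc3)nn2-c2ccccc2)cc1` gives 5%. Compound 2 therefore stands second highest of the three, with compound 1 sitting higher by a margin beyond the scatter and compound 3 lower by a margin beyond the scatter. Compound 4 `O=C(NO)c1ccc(NCc2nc(-c3ccc(Cl)c(Cl)c3)nn2-c2ccccc2)cc1` is not yet measured; it differs from compound 2 in one place: 3,4-dichlorophenyl in place of isoquinolin-5-yl on an aromatic carbon. Among the compounds with values here, no step between measured compounds that differ in one place is available, so the size of this change can only be guessed. A modest rise, close to the edge of the scatter, is expected for a number 9.8 percentage points higher from compound 2 to compound 4 (within the scatter). Compound 4 is accordingly estimated at 50%, within 30% to 70%.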

Compound 4, a percentage reported as inhibition, at one concentration (the size of the read-out at that concentration, not a potency): 34.5%
Beside the measured number, compound 4's estimate is 15.5 percentage points above it; measured number inside the range.
By their numbers in this assay, from the lowest: compound 3; then compounds 4 and 2 (each within the scatter of the next); then compound 1.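

In this assay, 3,4-dichlorophenyl in place of isoquinolin-5-yl gives a number 5.7 percentage points lower from compound 2 to compound 4 (within the scatter), the first one-place step available, so on this aromatic carbon the two groups cannot be told apart. Compound 4 loses the hydrogen-bond acceptor and the second ring of isoquinolin-5-yl, yet compound 2 and compound 4 stand within the scatter of each other. Nothing available explains this result. As far as these compounds go, whether an amine, a carboxylic acid or a small alkyl chain on this carbon would give a similar number remains open. So does whether the step would hold on the core of compound 1.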